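Sulfamoyl for phenoxy on an aminomethyl cyclohexanol scaffold

The source may report more compounds than this note shows. Statements on the series, on what has been measured and on what is new or still open speak of the compounds shown alone.

Three compounds have been measured in an ADME assay on MDCK cells (Canis lupus familiaris) for cytotoxicity, read by MTT assay, with a stated time of 3 days; on this read-out higher numbers stand for lower toxicity in this test and lower numbers for higher toxicity in this test:

Compound 1, `CC1(C)C[C@H](O)C[C@](C)(CNc2cccc(Cl)c2)C1`, gives 9700 nM
Compound 2, `CC1(C)C[C@H](O)C[C@](C)(CNc2cccc(C(F)(F)F)c2)C1`, gives 7800 nM
Compound 3, `CC1(C)C[C@H](O)C[C@](C)(CNc2cccc(Oc3ccccc3)c2)C1`, gives 6000 nM

Compound 3 shows the lowest number of the three, but the steps of a 1.6-fold lower number from compound 1 to compound 3 (0.21 log units; within the scatter) and a 1.3-fold lower number from compound 2 to compound 3 (0.11 log units; within the scatter) both lie within the scatter, as does a 1.2-fold lower number from compound 1 to compound 2 (0.09 log units; within the scatter), so the three compounds cannot be separated in this assay.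

Compound 4, `CC1(C)C[C@H](O)C[C@](C)(CNc2cccc(S(N)(=O)=O)c2)C1`, differs from compound 3 in one place: sulfamoyl in place of phenoxy on an aromatic carbon. Among the compounds with values here, none of the measured steps involves a sulfamoyl group, so there is no direct precedent for this change. What the three measured steps do show is that three quite different groups at this position of the shared core, chloro, trifluoromethyl and phenoxy, all give numbers within the scatter of one another. On that basis the sulfamoyl analogue is expected to behave similarly, and the estimated step from compound 3 to compound 4 is a 1.3-fold higher number from compound 3 to compound 4 (0.12 log units; within the scatter), that is, no movement beyond the scatter.

Compound 4 is therefore estimated at 8000 nM in this assay, with a range from 3500 nM to 18000 nM.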

Compound 4, half-maximal cytotoxic concentration: > 100000 nM
Compound 4: a limit, no number (the forecaster's own chance of this, stated with the estimate: 15%); at least 12-fold (1.09 log units) between middle value and limit.
By their numbers in this assay, from the lowest: compounds 3, 2 and 1 (each within the scatter of the next). At a limit, above all of these: compound 4.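

In this assay compound 4 gives > 100000 nM, which is a limit and not a number. Chloro, trifluoromethyl and phenoxy had left this position looking indifferent, but sulfamoyl separates clearly from all three: an at least 16-fold higher number from compound 3 to compound 4 (1.22 log units; beyond the scatter), an at least 12-fold higher number from compound 2 to compound 4 (1.10 log units; beyond the scatter) and an at least 10-fold higher number from compound 1 to compound 4 (1.01 log units; beyond the scatter), each beyond the scatter and each pointing to lower toxicity in this test. The position on the shared core can therefore move this read-out by a large margin, so the earlier agreement among three different groups did not extend to every group placed here, and the full size of the change stays unknown since only its lower bound can be read: the limit of > 100000 nM in this assay, at which 1 of the 4 values shown sits.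

The compounds shown do not tell whether this shift belongs to sulfamoyl alone or would also appear with a methylsulfonyl group, a primary carboxamide or a carboxylic acid in the same place. They also leave open whether the hydrogens on the sulfamoyl nitrogen matter, which an N-methyl sulfonamide would address, and whether sulfamoyl would give the same shift at another place on the aromatic ring.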